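This account rests on a few compounds, and the source may have more. Where it says the series, first, only, none or still open, it means among the compounds named here.

Compound 1, `Cc1ccc2c(=O)c(CSC(=S)N3CCCCC3)coc2c1`, in a functional assay on SW480 cells (Homo sapiens) for antiproliferative activity, read by MTT assay, with a stated time of 72 h; a lower number here means a stronger inhibitor, a higher number a weaker inhibitor: > 25000 nM, a limit of the assay.
Compound 2, `Cc1ccc2c(=O)c(CSC(=S)N3CCCC3)coc2c1`: 5900 nM.

Compound 2 holds the only number shown; compound 1 sits at the limit (the limit of > 25000 nM in this assay, at which 1 of the 2 values shown sits). Among the compounds with values here, the one measured step, an at least 4.2-fold lower number from compound 1 to compound 2 (0.62 log units; beyond the scatter), is the sole guide. Within the data shown here, compound 3, `Cc1ccc2c(=O)c(CSC(=S)N(C(C)C)C(C)C)coc2c1`, differs from compound 2 by diisopropylamino in place of pyrrolidin-1-yl on a thiocarbonyl carbon, a change no measured step covers. Compound 3 is therefore expected to stay close to compound 2, with a 1.5-fold higher number from compound 2 to compound 3 (0.18 log units; within the scatter), an estimate of 9000 nM, ranging from 3000 nM to 30000 nM.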

Compound 3, half-maximal inhibitory concentration: > 25000 nM
Compound 3 was reported as a limit; the forecaster's own chance of this, stated with the estimate: 25%; at least 2.7-fold (0.44 log units) between middle value and limit.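

In this assay, diisopropylamino in place of pyrrolidin-1-yl gives an at least 4.2-fold higher number from compound 2 to compound 3 (0.62 log units; beyond the scatter). Together with the earlier step, this leaves pyrrolidin-1-yl as the only one of the three groups shown on the thiocarbonyl carbon to give a number, so the ring alone does not account for the result, since the piperidin-1-yl ring of compound 1 also fails to give one. Compound 3 stands at a limit of the assay, as compound 1 does, and the step between these two cannot be read: the limit of > 25000 nM in this assay, at which 2 of the 3 values shown sit.

The compounds shown leave open whether dimethylamino, azetidin-1-yl or morpholin-4-yl on the thiocarbonyl carbon would give a number at all, and how any of them would compare with compound 2.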